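Sulfamide to sulfamate: one hexyl chain for two allyl groups

A few compounds are considered here, and "the series" means these few. Any claim that something is new, unique, unknown or untested is made for them only; others in the source may bear on it.

Compound 1 `C=CCN(CC=C)S(=O)(=O)NC(=O)Nc1c(C(C)C)cccc1C(C)C` shares its core with compound 2 `CCCCCCN(CCCCCC)S(=O)(=O)NC(=O)Nc1c(C(C)C)cccc1C(C)C` and compound 3 `CCCCCCOS(=O)(=O)NC(=O)Nc1c(C(C)C)cccc1C(C)C`, which has not yet been measured. Within the data shown here, in an assay on liver for inhibition of sterol O-acyltransferase 1 (Rattus norvegicus), using microsomes (on this read-out higher numbers stand for weaker inhibition and lower numbers for stronger inhibition), compound 1 gives 2700 nM, the highest of the two numbers known, while compound 2 gives 510 nM. Compound 3 differs from compound 1 in one place: hexyloxy in place of diallylamino on a sulfonyl sulfur. Among the measured compounds shown here, no measured pair shows this change, so the expectation rests on the two values above. Given that compound 2 reaches 510 nM, the step of a 2.3-fold lower number from compound 1 to compound 3 (0.35 log units; beyond the scatter) is expected to lower the number, though less far. Compound 3 is therefore estimated at 1200 nM, with a range from 300 nM to 5000 nM.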

Compound 3, half-maximal inhibitory concentration: 27000 nM
The estimate for compound 3 lay 23-fold (1.35 log units) below the measured number; measured number above the stated range.
By their numbers in this assay, from the lowest: compound 2; then compound 1; then compound 3.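

In this assay, hexyloxy in place of diallylamino on the sulfonyl sulfur gives a 10-fold higher number from compound 1 to compound 3 (1.00 log units; beyond the scatter), although both groups hold the same count of heavy atoms. Among these compounds, the earlier compounds both kept a nitrogen on this sulfur, so this is the first sign that the number here can rise sharply when an oxygen-linked chain takes its place. No supporting measurement bears on why the number rises.

The compounds shown leave open whether the rise follows the oxygen link or the loss of a second chain. A hexylamino group on the same sulfur would separate these two changes.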